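The source may report more compounds than this note shows. Statements on the series, on what has been measured and on what is new or still open speak of the compounds shown alone.

Compound 1: `COc1cc(C2=NN(C(C)=O)C(c3ccc(F)cc3)O2)cc(OC)c1OC`, giving 0.1%
Compound 2: `COc1cc(C(=O)N/N=C/c2c(Cl)cccc2Cl)cc(OC)c1OC`, giving 52.1%

In a functional assay on PC-3 cells (Homo sapiens) for antiproliferative activity, read by MTT assay, tested at 5 uM (a higher number here means a stronger effect of the compound at the concentration tested, a lower number a weaker effect), compound 1 gives 0.1%, the lowest of the two numbers; the nearest is compound 2 with 52.1%, a gap beyond the scatter. For the measured compounds named here, the two compounds are built on different cores, and no single-point step joins them, so their values only show where each stands. Compound 3, `COc1cc(C2=NN(C(C)=O)C(c3ccc(Cl)c([N+](=O)[O-])c3)O2)cc(OC)c1OC`, has not been measured. It differs from compound 1 in one place: 4-chloro-3-nitrophenyl in place of 4-fluorophenyl on a saturated ring carbon. No measured step of this kind exists among the compounds shown. Since compound 1 sits at 0.1%, a move downward beyond the scatter is hardly possible, so the step of a number 9.9 percentage points higher from compound 1 to compound 3 (within the scatter) is expected to be a small rise at most, and quite possibly none beyond the scatter. Compound 3 is estimated at 10%, with a range from 0% to 35%.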

Compound 3, a percentage reported as inhibition, at one concentration (the size of the read-out at that concentration, not a potency): 61.4%
Compound 3: the middle estimate sits 51.4 percentage points below what was measured; measured number outside the range, above it.
By their numbers in this assay, from the lowest: compound 1; then compounds 2 and 3 (each within the scatter of the next).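

In this assay the swap of 4-fluorophenyl for 4-chloro-3-nitrophenyl on the saturated ring carbon gives a number 61.3 percentage points higher from compound 1 to compound 3 (beyond the scatter) and so shows that this position can decide the read-out. For the compounds shown here, it also shows that the shared core is not without effect in itself, which compound 1 alone could not reveal and which no single-place step among the earlier compounds could test. Nothing available here explains why this one change has so large an effect.

From the compounds shown here alone, the step alters two things at once, the halogen and the added nitro group, so it remains open whether a phenyl ring carrying only the chlorine or only the nitro group would keep this effect. Also open, going by these compounds, is how an amine or a carboxylic acid on that ring would behave at this position.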